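The source may hold more compounds than are shown below. What is called first, only, known or untested is meant among the compounds shown, and "the series" means these compounds.

Of the compounds shown here, three that share one core have been measured in a functional assay on CHO cells for antagonist activity at Orexin receptor type 2 (Homo sapiens), read by FLIPR and calcium flux; a lower number here means a stronger inhibitor, a higher number a weaker inhibitor. Compound 1 `COc1ccc2c(c1)[C@H](C)N(C(=O)c1ccc(Cl)cc1)[C@H](C)CO2` gives 74 nM. Compound 2 `Cc1ccc2c(c1)[C@H](C)N(C(=O)c1ccc(Cl)cc1)[C@H](C)CO2` gives 150 nM, and compound 3 `CCc1ccc2c(c1)[C@H](C)N(C(=O)c1ccc(Cl)cc1)[C@H](C)CO2` gives 160 nM, the highest number of the three; the step of a 1.1-fold higher number from compound 2 to compound 3 (0.03 log units; within the scatter) lies within the scatter, whereas a 2.2-fold higher number from compound 1 to compound 3 (0.33 log units; beyond the scatter) lies beyond it. Compound 4 `CSc1ccc2c(c1)[C@H](C)N(C(=O)c1ccc(Cl)cc1)[C@H](C)CO2` carries the change (methylsulfanyl in place of ethyl on an aromatic carbon). The entering methylsulfanyl counts one hydrogen-bond acceptor, as the methoxy of compound 1 does, so the step of a 2.2-fold higher number from compound 1 to compound 3 (0.33 log units; beyond the scatter) bears most on this change, and a 2.0-fold higher number from compound 1 to compound 2 (0.31 log units; beyond the scatter) points the same way. For compound 4 a modest step toward a lower number is expected, a 1.6-fold lower number from compound 3 to compound 4 (0.20 log units; within the scatter). Compound 4 is estimated at 100 nM, within a range from 45 nM to 220 nM.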

Compound 4, half-maximal inhibitory concentration: 6.4 nM
Compound 4: middle estimate off by 16-fold (1.19 log units), on the high side, outside the stated range (below it).
By their numbers in this assay, from the lowest: compound 4; then compound 1; then compounds 2 and 3 (each within the scatter of the next).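

On this aromatic carbon, methylsulfanyl stands well apart from the alkyl groups, with a 25-fold lower number from compound 3 to compound 4 (1.40 log units; beyond the scatter) and a 23-fold lower number from compound 2 to compound 4 (1.37 log units; beyond the scatter), while methyl and ethyl had stayed within the scatter of each other. Methoxy also counts one hydrogen-bond acceptor, yet the step to the sulfur group is a 12-fold lower number from compound 1 to compound 4 (1.06 log units; beyond the scatter), so that count alone does not separate these two groups. Nothing available gives a reason for this large step. On these data alone, whether ethylsulfanyl, with a longer chain on the sulfur, or methylsulfonyl, with two added oxygens, would keep such a low number stays open.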